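The source may report more compounds than this note shows. Statements on the series, on what has been measured and on what is new or still open speak of the compounds shown alone.

Measured so far:
- compound 1, `C1=C(c2cccnc2)CC2CNCC1C2`: 0.2 nM
- compound 2, `CN1CC2C=C(c3cncc(Cl)c3)CC(C2)C1`: 9.6 nM

In an in vitro assay on SH-EP1 cells for displacement of a labelled ligand from Neuronal acetylcholine receptor; alpha4/beta2 (Homo sapiens) (a lower number here means a stronger inhibitor, a higher number a weaker inhibitor), compound 1 gives 0.2 nM, and compound 2 gives 9.6 nM, the higher of the two numbers; the gap between them lies beyond the scatter. The two compounds differ in more than one place, so the values alone can be read, not a step.

Compound 3, `Clc1cncc(C2=CC3CNCC(C2)C3)c1`, has not yet been measured in this assay. It differs from compound 2 in one place: hydrogen in place of methyl on an amine nitrogen in a ring. Given that compound 1, which also carries hydrogen on that amine nitrogen, gives 0.2 nM, the author expects the step from compound 2 to compound 3 to be a large one toward a lower number, well beyond the scatter, namely a 19-fold lower number from compound 2 to compound 3 (1.28 log units; beyond the scatter). The estimate for compound 3 in this assay is 0.5 nM, with a range from 0.1 nM to 3 nM.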

Compound 3, inhibition constant: 0.4 nM
Estimate against measurement, compound 3: 1.3-fold (0.10 log units) above; the range from low to high includes it.
By their numbers in this assay, from the lowest: compounds 1 and 3 (each within the scatter of the next); then compound 2.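

In this assay, among these compounds, the amine nitrogen in the ring is the first place where a single change can be read. Hydrogen in place of methyl there gives a 24-fold lower number from compound 2 to compound 3 (1.38 log units; beyond the scatter), a large step, so the methyl on this nitrogen matters greatly on the chlorinated compounds. Chloro in place of hydrogen on the aromatic carbon gives a 2.0-fold higher number from compound 1 to compound 3 (0.30 log units; within the scatter), so of the two single changes read so far, only the one at the nitrogen moves the number beyond the scatter.

On these data alone, how an ethyl group on that nitrogen would compare with methyl and hydrogen stays open, as does whether a fluoro or methoxy group on the aromatic carbon would also leave the number within the scatter. What lies behind the size of either step is not addressed by any evidence at hand.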